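The source may hold more compounds than are shown below. What is called first, only, known or untested is meant among the compounds shown, and "the series" means these compounds.

Values measured so far in a functional assay on U-251 cells (Homo sapiens) for inhibition, read by sulforhodamine B assay, with a stated time of 72 h; on this read-out lower numbers stand for an effect already at smaller amounts and higher numbers for an effect only at larger amounts of compound:
- compound 1 `CSc1ccc(C(=O)/C=C/c2ccc([N+](=O)[O-])o2)cc1` gives 14200 nM
- compound 2 `O=C(/C=C/c1ccc([N+](=O)[O-])o1)c1ccc(N2CCCC2)cc1` gives 35900 nM

Of these two compounds, compound 2 has the higher number, so it needs the larger amount to reach its effect in this assay. The next compound to consider is compound 3 `O=C(/C=C/c1ccc([N+](=O)[O-])o1)c1ccc(N2CCNCC2)cc1`, which keeps the shared core and changes one group, with piperazin-1-yl in place of pyrrolidin-1-yl on an aromatic carbon.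

Among the compounds with values here, only one measured step bears on this place, a 2.5-fold higher number from compound 1 to compound 2 (0.40 log units; beyond the scatter), where pyrrolidin-1-yl replaced methylsulfanyl. That step is modest, and it is only a rough guide, as it involves a different pair of groups. Within the data shown here, no compound carrying piperazin-1-yl has been measured, so the data do not settle the direction. A change of the same modest size is possible either way, but no step beyond the scatter is the expectation. The expected change is a 1.4-fold lower number from compound 2 to compound 3 (0.14 log units; within the scatter). For compound 3 the estimated value is 26000 nM, with an expected range from 9000 nM to 70000 nM.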

Compound 3, half-maximal effective concentration: 16700 nM
Compound 3: middle estimate off by 1.6-fold (0.19 log units), on the high side; the measured number falls inside the stated range.
By their numbers in this assay, from the lowest: compounds 1 and 3 (each within the scatter of the next); then compound 2.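

In this assay, the aromatic carbon para to a large group responds to a change between two non-aromatic rings joined through nitrogen: with piperazin-1-yl in place of pyrrolidin-1-yl, the result is a 2.1-fold lower number from compound 2 to compound 3 (0.33 log units; beyond the scatter), a modest shift. Set against methylsulfanyl, piperazin-1-yl gives a 1.2-fold higher number from compound 1 to compound 3 (0.07 log units; within the scatter), so compound 1 and compound 3 cannot be told apart here, and the higher number of compound 2 goes with pyrrolidin-1-yl and not with every non-aromatic nitrogen ring at this place. Nothing measured here gives a reason for the shift.

Piperazin-1-yl differs from pyrrolidin-1-yl in both ring size and its second nitrogen, so the compounds shown cannot separate these two changes; piperidin-1-yl, with carbon in place of that nitrogen, and morpholin-4-yl, with oxygen there, would keep the six-membered ring while changing only that atom. A 4-methylpiperazin-1-yl group would further show whether the hydrogen on the second nitrogen matters to the number at this position.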